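The compounds below may be only part of what the source reports. "The series", "measured", "known", "first", "only" and "open" are said of these compounds alone.

Measured so far:
compound 1, `O=C(OCc1ccccc1)[C@@H]1CCCN1C(=O)CN(c1ncnc2c1ncn2C1CCCCO1)C1CC1` — 7.85%
compound 2, `NC(=O)C[C@H](NC(=O)CN(c1nc(Cl)nc2[nH]cnc12)C1CC1)C(=O)O` — 7.51%
compound 3, `CCOC(=O)CN(c1nc(Cl)nc2c1ncn2C1CCCCO1)C1CC1` — 11.9%

All three readings come from a functional assay on the whole organism (Tail, strain ICR) with Mus musculus as the target, in the tail flick test, with a stated time of 150 min, at a dose of 25 umol/kg by the oral route; a lower number here means a weaker effect, a higher number a stronger effect of the compound at the dose given. In this assay compound 1 gives 7.85%, compound 2 gives 7.51% and compound 3 gives 11.9%. Compound 2 has the smallest number of the three, but its gap to compound 1 and its gap to compound 3 both lie within the scatter of repeated measurements, so none of these three compounds can be called weaker or stronger than another; all three sit low on the scale.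

Compound 4, `CSCC[C@H](NC(=O)CN(c1nc(Cl)nc2[nH]cnc12)C1CC1)C(=O)O`, is not yet measured. It differs from compound 2 in one place: (methylsulfanyl)methyl in place of carbamoyl on a saturated chain carbon, two bonds along the chain from an amide-type nitrogen and a carbonyl carbon. The shared core and the rest of the chain are unchanged.

Among the compounds with values here, no step between measured compounds is available to show what this kind of change does in this assay. With the three measured compounds all close together and low, the expectation for compound 4 is a step from compound 2 of no size beyond the scatter, a number 0.5 percentage points higher from compound 2 to compound 4 (within the scatter), in no particular direction. Compound 4 is therefore estimated at 8%, expected to fall between 2% and 16%.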

Compound 4, a percentage reported as activity, at one dose (the size of the read-out at that dose, not a potency): 4.14%
Estimate against measurement, compound 4: 3.9 percentage points above, within the range that was stated.
By their numbers in this assay, from the lowest: compounds 4, 2, 1 and 3 (each within the scatter of the next).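

In this assay, putting (methylsulfanyl)methyl in place of carbamoyl on a saturated chain carbon, two bonds along the chain from an amide-type nitrogen and a carbonyl carbon, gives a number 3.4 percentage points lower from compound 2 to compound 4 (within the scatter). Within the data shown here, this is the first reading of a change at this place, and it shows that a swap of some size in atom content, with sulfur entering, nitrogen and oxygen leaving and the hydrogen-bond donor of the carbamoyl gone, does not move the read-out beyond the usual scatter, so neither group can be ranked over the other here. Nothing measured on these compounds accounts for this outcome or tells what the two groups do in the animal.

Still open, from the compounds shown here alone, is whether any other group at this place, such as a primary amine or a longer alkyl chain, would take the number clear of the scatter. Both compounds in this step also sit low on the scale at a single dose and a single time, so the reading cannot show whether the two groups would separate under other conditions.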